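A few compounds are considered here, and "the series" means these few. Any claim that something is new, unique, unknown or untested is made for them only; others in the source may bear on it.

Measured in an ADME assay on the whole organism (Rattus norvegicus), at a dose of 2 mg/kg by the oral route; a higher number here means more compound in the circulation at the dose given, a lower number less compound in the circulation:
Compound 1 `COc1cc(OCc2cccc(-c3ccc(OC)nc3)c2)c2cc(-c3cn4nc(OC)sc4n3)oc2c1`: 1800 ng.h/mL
Compound 2 `COc1cc(OCc2cccc(-c3ccc(C#N)cn3)c2)c2cc(-c3cn4nc(OC)sc4n3)oc2c1`: 464 ng.h/mL
Compound 3 `COc1cc(OCc2cccc(-c3cnc(OC)nc3)c2)c2cc(-c3cn4nc(OC)sc4n3)oc2c1`: 1030 ng.h/mL

Two steps fix where the third of these values stands: there is a 1.7-fold lower number from compound 1 to compound 3 (0.24 log units; within the scatter), and there is a 2.2-fold higher number from compound 2 to compound 3 (0.35 log units; beyond the scatter). The next case is compound 4 `COc1cc(OCc2cccc(-c3cnc(OC)cn3)c2)c2cc(-c3cn4nc(OC)sc4n3)oc2c1`, whose change is 5-methoxypyrazin-2-yl in place of 2-methoxypyrimidin-5-yl on an aromatic carbon, on an aromatic carbon meta to a large group.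

Within the data shown here, no measured step makes this exact exchange. Among the measured compounds shown here, the nearest precedent also keeps a methoxy group on the incoming ring: 2-methoxypyrimidin-5-yl replacing 6-methoxypyridin-3-yl gave a 1.7-fold lower number from compound 1 to compound 3 (0.24 log units; within the scatter). The only clear moves involve 5-cyanopyridin-2-yl, as in a 3.9-fold lower number from compound 1 to compound 2 (0.59 log units; beyond the scatter), and compound 4 does not carry that group. No step beyond the scatter is therefore expected in this assay, and the expected change is a 1.0-fold lower number from compound 3 to compound 4 (0.01 log units; within the scatter). The estimate for compound 4 is 1000 ng.h/mL, with an expected range of 430 ng.h/mL to 2300 ng.h/mL.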

Compound 4, area under the concentration-time curve: 722 ng.h/mL
Compound 4: middle estimate off by 1.4-fold (0.14 log units), on the high side; the measured number falls inside the stated range.
By their numbers in this assay, from the lowest: compounds 2, 4, 3 and 1 (each within the scatter of the next, the first and the last beyond it).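

Within this assay, rearranging the same atoms from 2-methoxypyrimidin-5-yl to 5-methoxypyrazin-2-yl on this aromatic carbon stays within the scatter (a 1.4-fold lower number from compound 3 to compound 4 (0.15 log units; within the scatter)). Keeping a methoxy group on the incoming ring does not alone keep the number close to that of the 6-methoxypyridin-3-yl compound (a 2.5-fold lower number from compound 1 to compound 4 (0.40 log units; beyond the scatter)), and the 5-methoxypyrazin-2-yl compound also stays within the scatter of the 5-cyanopyridin-2-yl compound (a 1.6-fold higher number from compound 2 to compound 4 (0.19 log units; within the scatter)). No measurement offered here explains these differences.

The compounds shown leave open how the number would respond if an amine or a longer alkoxy chain took the place of the methoxy group on this ring. They also leave open whether these small differences would hold at another dose or by another route.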